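A Second Chloro on the Shared Core of Compound 1

The compounds below may be only part of what the source reports. "The series", "measured", "known", "first", "only" and "open" are said of these compounds alone.

Compound 1 `ClCc1ccc(Cn2cnc3c(Cl)ncnc32)cc1` was tested in a functional assay on U-251 cells (Homo sapiens) for cytotoxicity, read by sulforhodamine B assay, with a stated time of 48 h (a higher number here means a weaker inhibitor of growth, a lower number a stronger inhibitor of growth), where compound 1 gives 1250 nM. Among the three compounds measured so far, this is the second highest number. Compound 3 `ClCc1cccc(Cn2cnc3c(Cl)ncnc32)c1` gives 1820 nM in this assay; the two values lie within the scatter of each other. Compound 2 `ClCc1ccccc1Cn1cnc2c(Cl)nc(Cl)nc21` gives 310 nM in this assay, a number beyond the scatter below that of compound 1; compound 2 differs from compound 1 in more than one place, so only its two values are set side by side here.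

Compound 4 `ClCc1ccc(Cn2cnc3c(Cl)nc(Cl)nc32)cc1` has not yet been measured. It differs from compound 1 in one place: chloro in place of hydrogen on an aromatic carbon, between two ring nitrogen atoms. Among the measured compounds shown here, no measured pair shows this single change on its own. For the measured compounds named here, the one measured compound carrying the second chloro, compound 2, gives the lowest number in this assay, though with another placement of the chloromethyl group. Compound 4 is therefore expected to give a lower number than compound 1 in this assay, with an expected step of a 2.3-fold lower number from compound 1 to compound 4 (0.36 log units; beyond the scatter), more modest than the gap to compound 2 and carrying wide uncertainty. The estimate for compound 4 in this assay is 550 nM, within 200 nM to 1500 nM.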

Compound 4, concentration for 50% growth inhibition: 2040 nM
For compound 4 the middle estimate is 3.7-fold (0.57 log units) below the measured one, and the stated range ends below it.
By their numbers in this assay, from the lowest: compound 2; then compounds 1, 3 and 4 (each within the scatter of the next).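

Among the compounds shown here, the first direct reading of this change in this assay is a 1.6-fold higher number from compound 1 to compound 4 (0.21 log units; within the scatter): with the chloromethyl group placed as in compound 1, chloro in place of hydrogen on this aromatic carbon, between two ring nitrogen atoms, has no effect that can be told from the scatter. The second chloro is thus not enough on its own to give a low number, for compound 2 gives 310 nM and compound 4 gives 2040 nM, though both carry it. Nothing available here accounts for this result.

Going by these compounds, it remains open whether the second chloro counts for anything when the chloromethyl group sits as in compound 2 or compound 3, and so how much of the low number of compound 2 belongs to the chloro and how much to the placement of the chloromethyl group. Also open, on these data alone, is how an amine, a methoxy group or a longer chain would read in this assay at this same position, where so far only hydrogen and chloro appear.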